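Methylating a phenol oxygen in a flavone series

The source may report more compounds than this note shows. Statements on the series, on what has been measured and on what is new or still open speak of the compounds shown alone.

Compound 1, `COC(=O)c1c(-c2ccc(O)cc2)oc2ccc(OC)cc2c1=O`, gives > 25 ug/mL in a functional assay on Malme-3M cells (Homo sapiens) for cytotoxicity, read by MTT assay, with a stated time of 6 days (on this read-out lower numbers stand for an effect already at smaller amounts and higher numbers for an effect only at larger amounts of compound), which is a limit of the assay.
Compound 2, `COc1ccc2oc(-c3ccc(O)cc3)c(C(=O)O)c(=O)c2c1`, gives > 25 ug/mL in this assay, again a limit.
Compound 3, `COc1cc(-c2cc(=O)c3ccc(O)cc3o2)cc(OC)c1OC`, gives > 25 ug/mL in this assay, also a limit.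

Compound 4, `COc1ccc2c(=O)cc(-c3cc(OC)c(OC)c(OC)c3)oc2c1`, has not been measured. It differs from compound 3 by methyl in place of hydrogen on an oxygen on an aromatic ring. The same kind of change is already measured once: compound 1 differs from compound 2 by methyl in place of hydrogen on an oxygen next to a carbonyl group, where the place is an oxygen next to a carbonyl group rather than an oxygen on an aromatic ring. That earlier step, a step that the two limits leave unreadable from compound 2 to compound 1, cannot be sized, since (the limit of > 25 ug/mL in this assay, at which 3 of the 3 values shown sit). How the core of compound 3 differs from that of compound 2 is not broken down here. The step that the limit leaves unreadable from compound 3 to compound 4 is expected to be small, resting on (the limit of > 25 ug/mL in this assay, at which 3 of the 3 values shown sit). Compound 4 is therefore estimated at 30 ug/mL, between 10 ug/mL and 80 ug/mL.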

Compound 4, concentration for half-maximal effect: > 25 ug/mL
Compound 4: no number, only a limit (the forecaster's own chance of this, stated with the estimate: 75%); the middle value is on the limit's open side.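

No step can be read from compound 3 to compound 4, since each gives only a limit: the limit of > 25 ug/mL in this assay, at which 4 of the 4 values shown sit.

The compounds shown leave open whether hydroxy to methoxy changes the effect in this assay at all.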